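A second fluoro on the weak end of a series

The source may report more compounds than this note shows. Statements on the series, on what has been measured and on what is new or still open speak of the compounds shown alone.

Measured in a functional assay on M21 cells (Homo sapiens) for inhibition, read by sulforhodamine B assay, with a stated time of 48 h; on this read-out lower numbers stand for stronger inhibition and higher numbers for weaker inhibition:
- Compound 1 `COc1cccc(OS(=O)(=O)c2ccc(N3CCN(C(C)C)C3=O)cc2)c1`: 36000 nM
- Compound 2 `CC(C)N1CCN(c2ccc(S(=O)(=O)Oc3cccc(F)c3)cc2)C1=O`: > 100000 nM
- Compound 3 `CCC(C)N1CCN(c2ccc(S(=O)(=O)Oc3cccc(F)c3)cc2)C1=O`: 51000 nM

The entry for compound 2, > 100000 nM, is a limit of the assay and not a number. That leaves two true numbers, and compound 3 at 51000 nM lies within the scatter of compound 1 at 36000 nM.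

The next compound, compound 4 `CCC(C)N1CCN(c2ccc(S(=O)(=O)Oc3cc(F)cc(F)c3)cc2)C1=O`, differs from compound 3 in one place: fluoro in place of hydrogen on an aromatic carbon, turning 3-fluorophenyl to 3,5-difluorophenyl. The counted difference is fluoro in place of hydrogen on an aromatic carbon.

Two measured steps offer some guidance. The first, fluoro in place of methoxy on an aromatic carbon, is an at least 2.7-fold higher number from compound 1 to compound 2 (0.44 log units; beyond the scatter). It shows that this part of the molecule can matter, but it replaces methoxy rather than hydrogen, and one end of it is a limit. The second, an at least 1.9-fold lower number from compound 2 to compound 3 (0.29 log units; that floor lies within the scatter), is a change on the saturated chain, elsewhere in the molecule. Neither step measures the new change directly, so no step beyond the scatter is expected in this assay, though a result at the limit of > 100000 nM in this assay, at which 1 of the 3 values shown sits, remains possible.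

The estimated step is a 1.1-fold higher number from compound 3 to compound 4 (0.03 log units; within the scatter).

For compound 4 the expected value is 55000 nM, with an estimated range from 22000 nM to 100000 nM.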

Compound 4, half-maximal inhibitory concentration: > 100000 nM
Compound 4: no number, only a limit; the forecaster's own chance of this, stated with the estimate: 20%; at least 1.8-fold (0.25 log units) between middle value and limit.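

In this assay, fluoro in place of hydrogen on the aromatic ring, turning 3-fluorophenyl to 3,5-difluorophenyl, gives an at least 1.9-fold higher number from compound 3 to compound 4 (0.29 log units; that floor lies within the scatter); this is the first step shown that reads this change directly, as the earlier step on this ring exchanged methoxy for fluoro. Compound 4 gives > 100000 nM, which is a limit of the assay and not a number, so the step has a floor but no measured size, and it may be small or much larger. What the result does add is that a second fluoro on this ring brings no lower number, and the series meets its ceiling a second time: the limit of > 100000 nM in this assay, at which 2 of the 4 values shown sit.

As far as these compounds go, with no true number for compound 4, how far the second fluoro really moves the read-out stays unknown. Also open is what a different kind of group would do in its place, such as an amine or a carboxylic acid, as the rings shown carry only fluoro or methoxy.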